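The compounds below may be only part of what the source reports. "The series", "measured", "known", "first", "only" and "open" are said of these compounds alone.

Working notes on the series. The shared core carries two methoxy groups and a methyl in compound 1 `COc1nc(C)c(CCO)c(OC)n1`, compound 2 `COc1nc(C)c(CCF)c(OC)n1` and compound 4 `COc1nc(C)c(CCOC(C)=O)c(OC)n1`, while compound 3 `COc1nc(Cl)nc(C)c1CCF` carries chloro in place of one methoxy. In a functional assay on HCT-116 cells (Homo sapiens) for antiproliferative activity, read by MTT assay, with a stated time of 24 h (on this read-out lower numbers stand for stronger inhibition and higher numbers for weaker inhibition), compound 1 gives > 100000 nM, which is a limit of the assay and not a number. In this assay compound 2 gives > 100000 nM, again a limit. Compound 3 likewise gives > 100000 nM, a limit. All three values sit at the same limit (the limit of > 100000 nM in this assay, at which 3 of the 3 values shown sit), so the step from compound 1 to compound 2 reads a step that the two limits leave unreadable from compound 1 to compound 2, and the step from compound 2 to compound 3 reads a step that the two limits leave unreadable from compound 2 to compound 3. Compound 2 therefore stands at the limit, with no number to place it against compound 1 or compound 3.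

The step to compound 4 is acetoxy in place of fluoro on a saturated chain carbon, two bonds along the chain from an aromatic carbon. Going by the values given here, the nearest measured step is the one from compound 1 to compound 2, since it alters the same chain carbon, and it is unreadable; the step from compound 2 to compound 3 is unreadable too. No direction or size can be read from these. Compound 4 is expected to stay at the limit as well, the expected step from compound 2 being a step that the limit leaves unreadable from compound 2 to compound 4. The estimate for compound 4 in this assay is 150000 nM, within 30000 nM to 600000 nM.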

Compound 4, half-maximal inhibitory concentration: 40000 nM
Compound 4: the middle estimate sits 3.8-fold (0.57 log units) above what was measured; the measured number falls inside the stated range.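

Going by these compounds alone, on the saturated chain carbon, two bonds along the chain from an aromatic carbon, acetoxy gives the first readable number in this assay: the change from fluoro reads as an at least 2.5-fold lower number from compound 2 to compound 4 (0.39 log units; beyond the scatter), and acetyl in place of hydrogen on the oxygen reads as an at least 2.5-fold lower number from compound 1 to compound 4 (0.39 log units; beyond the scatter). Within the data shown here, the earlier steps cannot be read, so this is the first sign that a change at this chain position can bring the series off the limit. Both new steps give only a lower bound on size because each starts from a limit and not from a number: the limit of > 100000 nM in this assay, at which 3 of the 4 values shown sit.

The compounds shown leave open whether the shift needs the whole acetoxy group or whether an amine, a carboxylic acid or a longer acyl chain on the same carbon would also give a readable number. They also leave open whether acetoxy would still give a readable number with chloro in place of methoxy on the aromatic carbon, the change carried by compound 3.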